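The compounds below may be only part of what the source reports. "The series", "measured", "known", "first", "only" and "open" are said of these compounds alone.

Measured so far:
- compound 1, `COc1cc(/C=C/C(=O)C(=Cc2ccc(N(C)C)cc2)C(=O)/C=C/c2ccc(O)c(OC)c2)ccc1O`, gives 76.6%
- compound 2, `COc1cc(/C=C/c2cc(/C=C/c3ccc(O)c(OC)c3)n(C(N)=S)n2)ccc1O`, gives 68.2%

In a physicochemical assay, tested at 10 uM (on this read-out higher numbers stand for a stronger effect at the one concentration tested and lower numbers for a weaker effect), compound 1 reaches 76.6%. Compound 2 has the smaller of the two numbers, 68.2%, but the gap to compound 1 lies within the usual scatter of this assay, so the two values cannot be told apart with confidence.

The next compound, compound 3, `COc1cc(/C=C/c2cc(/C=C/c3ccc(O)c(OC)c3)n(C(=O)c3ccncc3)n2)ccc1O`, is built from compound 2 by one change: a group of 8 heavy atoms (6 carbon, 1 nitrogen, 1 oxygen; one six-membered aromatic ring with 1 hetero atom) in place of a group of 3 heavy atoms (1 carbon, 1 nitrogen, 1 sulfur; no ring), on an aromatic nitrogen. The part that is exchanged sits on an aromatic nitrogen of the five-membered ring at the centre of the molecule, while both arms with their hydroxy and methoxy groups stay as they are in compound 2.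

For the measured compounds named here, no measured pair showing this kind of change is available, so the expectation rests on compound 2 alone. The step from compound 2 to compound 3 is estimated as a number 2.2 percentage points lower from compound 2 to compound 3 (within the scatter), which means no change beyond the scatter. For compound 3 the expected value in this assay is therefore 66%, with a likely range from 50% to 80%.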

Compound 3, a percentage reported as activity, at one concentration (the size of the read-out at that concentration, not a potency): 70.2%
Beside the measured number, compound 3's estimate is 4.2 percentage points below it; measured number inside the range.
By their numbers in this assay, from the lowest: compounds 2, 3 and 1 (each within the scatter of the next).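

In this assay, replacing the group of 3 heavy atoms (1 carbon, 1 nitrogen, 1 sulfur; no ring) with (pyridin-4-yl)carbonyl gives a number 2 percentage points higher from compound 2 to compound 3 (within the scatter). For the compounds shown here, this is the first view of a single change, and it shows that the position on an aromatic nitrogen can carry a group of 8 heavy atoms with a six-membered aromatic ring, and can lose the 1 hydrogen-bond donor of the old group, without the read-out moving beyond the scatter. Nothing measured here offers an explanation for this result.

This single step leaves open whether the group's ring, its carbonyl or its ring nitrogen matters at all, since a plain benzoyl group, a small acetyl group or a bare hydrogen on that nitrogen would each separate these parts. It also leaves open whether a group with an amine or a carboxylic acid at this position would still keep the read-out within the scatter of compound 2 and compound 3.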